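The compounds below may be only part of what the source reports. "The series", "measured", "known", "first", "only" and "open" are said of these compounds alone.

The study concerns two closely related compounds built on one shared core. Compound 1 `COC(=O)/C=C/C1=CC[C@H]2C(C)(C)CCC[C@]2(C)[C@H]1C=O` carries a methoxycarbonyl group, and compound 2 `CCOC(=O)/C(C)=C/C1=CC[C@H]2C(C)(C)CCC[C@]2(C)[C@H]1C=O` an ethyl ester with an added methyl on the chain. In a functional assay on MCF7 cells (Homo sapiens) for inhibition, read by MTT assay, with a stated time of 72 h (a higher number here means a weaker inhibitor of growth, a lower number a stronger inhibitor of growth), compound 1 gives 7000 nM, the lower of the two numbers recorded. Compound 2 gives 27000 nM in this assay, a gap to compound 1 that lies beyond the usual scatter, so compound 1 stands as the stronger growth inhibitor of the pair.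

The next compound, compound 3 `CC(C)(C)OC(=O)/C=C/C1=CC[C@H]2C(C)(C)CCC[C@]2(C)[C@H]1C=O`, differs from compound 1 in one place: tert-butyl in place of methyl on an oxygen next to a carbonyl group. Among the compounds with values here, no measured pair isolates this change, so its effect cannot be read from the data. Compound 3 is expected to sit close to compound 1, with a step of a 1.7-fold higher number from compound 1 to compound 3 (0.23 log units; within the scatter) that, if it appears, would tend toward a weaker inhibitor but stay within the scatter. The estimate for compound 3 in this assay is 12000 nM, ranging from 4000 nM to 35000 nM.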

Compound 3, concentration for 50% growth inhibition: 32000 nM
For compound 3 the middle estimate is 2.7-fold (0.43 log units) below the measured one; measured number inside the range.
By their numbers in this assay, from the lowest: compound 1; then compounds 2 and 3 (each within the scatter of the next).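

In this assay, within the data shown here, tert-butyl in place of methyl on an oxygen next to a carbonyl group gives a 4.6-fold higher number from compound 1 to compound 3 (0.66 log units; beyond the scatter), the only step here that isolates a single change. It shows that this position is not indifferent to the group on the oxygen, and that this exchange weakens growth inhibition by more than the usual scatter. Nothing available explains why the step arises.

An isopropyl group on the same oxygen, a free carboxylic acid or an amide at this position could show whether the response is graded or depends on the ester itself. As far as these compounds go, the separate contribution of the added methyl on the chain of compound 2 also stays open, since that compound differs from compound 1 in more than one place.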